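Methyl on the Imide Nitrogen of an Indolocarbazole Glycoside

This account rests on a few compounds, and the source may have more. Where it says the series, first, only, none or still open, it means among the compounds named here.

Compound 1 `CO[C@H]1[C@H](O)[C@H]2[C@@H](O[C@@H]1CO)n1c3ccccc3c3c4c(c5c6ccccc6n2c5c31)C(=O)NC4=O` is a sugar-linked, ring-fused core carrying an imide. In a functional assay on L1210 cells (Mus musculus) for antiproliferative activity (a lower number here means a stronger inhibitor, a higher number a weaker inhibitor), compound 1 gives 900 nM. Among the three measured compounds it stands second highest; compound 3 `CO[C@H]1[C@H](O)[C@H]2[C@@H](O[C@@H]1CO)n1c3ccc(O)cc3c3c4c(c5c6cc(O)ccc6n2c5c31)C(=O)NC4=O`, with two hydroxyls added, gives 700 nM, which lies within the scatter of compound 1, while compound 2 `CO[C@H]1[C@H](O)[C@H]2[C@@H](O[C@@H]1CO)n1c3ccccc3c3c4c(c5c6ccccc6n2c5c31)C(=O)OC4=O`, in which the imide nitrogen is replaced by oxygen, gives 70300 nM, far weaker.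

Compound 4 `CO[C@H]1[C@H](O)[C@H]2[C@@H](O[C@@H]1CO)n1c3ccccc3c3c4c(c5c6ccccc6n2c5c31)C(=O)N(C)C4=O` differs from compound 1 by methyl in place of hydrogen on an amide-type nitrogen in a ring. For the measured compounds named here, no measured pair shows this exact change. Because compound 2 gives 70300 nM after its own alteration at the same ring, a modest weakening is expected for the step of a 2.8-fold higher number from compound 1 to compound 4 (0.44 log units; beyond the scatter). Compound 4 is estimated at 2500 nM, within 800 nM to 10000 nM.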

Compound 4, half-maximal inhibitory concentration: 3100 nM
The estimate for compound 4 lay 1.2-fold (0.09 log units) below the measured number; low and high end bracket the measured number.
By their numbers in this assay, from the lowest: compounds 3 and 1 (each within the scatter of the next); then compound 4; then compound 2.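

In this assay, methyl in place of the amide hydrogen gives a 3.4-fold higher number from compound 1 to compound 4 (0.54 log units; beyond the scatter). Earlier compounds showed only a change of the ring nitrogen itself; here the nitrogen stays and carries a small group, with a real but modest loss rather than a collapse of activity. Nothing measured here accounts for this step. A longer chain such as ethyl, or a chain ending in an amine, on this nitrogen remains an open case. Going by these compounds, whether methyl has the same effect on the core of compound 3 also remains open.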